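The compounds below may be only part of what the source reports. "The series", "measured", "known", "first", "only" and "open" are said of these compounds alone.

Three compounds have been measured in a functional assay on K562 cells (Homo sapiens) for antiproliferative activity, read by CCK-8 assay, with a stated time of 72 h; a lower number here means a stronger inhibitor, a higher number a weaker inhibitor:

compound 1 `Cc1cc(Nc2cc(N3CCN(C)CC3)nc(Nc3ccc([N+](=O)[O-])cc3)n2)n[nH]1` gave 137 nM
compound 2 `Cc1cc(Nc2cc(N3CCN(C)CC3)nc(Nc3ccc(Cl)cc3)n2)n[nH]1` gave 192 nM
compound 3 `Cc1cc(Nc2cc(N3CCN(C)CC3)nc(Nc3cccc([N+](=O)[O-])c3)n2)n[nH]1` gave 138 nM

Compound 1 and compound 2 differ in one place: chloro in place of nitro on an aromatic carbon. That change made a step of a 1.4-fold higher number from compound 1 to compound 2 (0.15 log units; within the scatter), so the two values are not told apart by this assay. Compound 3 has the same atoms as compound 1 joined differently: 3-nitrophenyl in place of 4-nitrophenyl on a nitrogen on an aromatic ring. Its step from compound 1 is a 1.0-fold higher number from compound 1 to compound 3 (0.00 log units; within the scatter), and from compound 2 it is a 1.4-fold lower number from compound 2 to compound 3 (0.14 log units; within the scatter), both within the scatter.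

Compound 4 `Cc1cc(Nc2cc(N3CCN(C)CC3)nc(Nc3cccc(Cl)c3)n2)n[nH]1` has not yet been measured in this assay. It stands to compound 3 as compound 2 stands to compound 1: chloro in place of nitro on an aromatic carbon. The place is not identical, since in compound 1 the group sits para to a large group and in compound 3 meta to a large group, so this is the same kind of change rather than the same change. Because the earlier step was a 1.4-fold higher number from compound 1 to compound 2 (0.15 log units; within the scatter), a step of about a 1.4-fold higher number from compound 3 to compound 4 (0.14 log units; within the scatter) is expected here. Compound 4 is therefore estimated at 190 nM, most likely between 90 nM and 400 nM.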

Compound 4, half-maximal inhibitory concentration: 97.2 nM
For compound 4 the middle estimate is 2.0-fold (0.29 log units) above the measured one; measured number inside the range.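

In this assay, chloro in place of nitro on the 3-nitrophenyl compound gave a 1.4-fold lower number from compound 3 to compound 4 (0.15 log units; within the scatter), and the two other new steps, a 2.0-fold lower number from compound 2 to compound 4 (0.30 log units; within the scatter) and a 1.4-fold lower number from compound 1 to compound 4 (0.15 log units; within the scatter), also stay inside the usual noise. Set beside its earlier counterpart, the nitro-to-chloro step has the opposite direction as printed, yet the two cannot be told apart: the same change on two cores in this assay, a 1.4-fold higher number (0.15 log units; within the scatter) from compound 1 to compound 2 and a 1.4-fold lower number (0.15 log units; within the scatter) from compound 3 to compound 4, 2.0-fold (0.30 log units) apart, within the scatter of two such steps This shows that the change left the number within the scatter on both cores, but it does not show a real effect of fixed size that carries from one core to the other, since neither step is large enough to be distinguished from repeat-measurement noise.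

The compounds shown carry only 3-nitrophenyl, 4-nitrophenyl, 3-chlorophenyl and 4-chlorophenyl groups at this site, so it stays open whether a methoxy group, an amine or a carboxylic acid there would give a step beyond the scatter. As far as these compounds go, the rest of the shared core is the same in all four compounds, so how a change elsewhere would read also stays open.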